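Capping the ring hydroxy of compound 2 with methyl

The source may report more compounds than this note shows. Statements on the series, on what has been measured and on what is new or still open speak of the compounds shown alone.

Compound 1 `CCCc1cccc(=O)n1Cc1ccc(-c2ccccc2-c2nn[nH]n2)cc1`: 1.1 mg/kg
Compound 2 `CCCc1cc(O)cc(=O)n1Cc1ccc(-c2ccccc2-c2nn[nH]n2)cc1`: 0.048 mg/kg
Compound 3 `CCc1cc(O)cc(=O)n1Cc1ccc(-c2ccccc2-c2nn[nH]n2)cc1`: 0.084 mg/kg

Among the three measured compounds, compound 2 gives the lowest number in a functional assay on the whole organism with Rattus norvegicus as the target; a lower number here means that less compound is needed, a higher number that more compound is needed for the effect; compound 3 lies within the scatter of it, while compound 1 sits far above, as the step of a 23-fold lower number from compound 1 to compound 2 (1.36 log units; beyond the scatter) shows to be well beyond the scatter. For the measured compounds named here, the one step on the propyl chain, a 1.8-fold higher number from compound 2 to compound 3 (0.24 log units; within the scatter), stays within the scatter.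

Compound 4 `CCCc1cc(OC)cc(=O)n1Cc1ccc(-c2ccccc2-c2nn[nH]n2)cc1` differs from compound 2 by methyl in place of hydrogen on an oxygen on an aromatic ring. Going by the values given here, no measured pair covers a change on this oxygen. The step that bears on it is the arrival of the hydroxy itself, a 23-fold lower number from compound 1 to compound 2 (1.36 log units; beyond the scatter), which was large; the step of a 1.8-fold higher number from compound 2 to compound 3 (0.24 log units; within the scatter) touches a different part of the molecule and is small. Among the compounds with values here, since the hydroxy was the one change that moved the number strongly, altering it is the part of the structure where a change of size is most plausible, and compound 4 is expected to land between compound 1 and compound 2 rather than to improve on compound 2. The expected step from compound 2 is a 6.3-fold higher number from compound 2 to compound 4 (0.80 log units; beyond the scatter), and compound 4 is estimated at 0.3 mg/kg, with a range from 0.08 mg/kg to 1.2 mg/kg.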

Compound 4, dose for 50% inhibition: 0.24 mg/kg
Beside the measured number, compound 4's estimate is 1.3-fold (0.10 log units) above it; the range from low to high includes it.
By their numbers in this assay, from the lowest: compounds 2 and 3 (each within the scatter of the next); then compound 4; then compound 1.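

Capping the oxygen shows that the hydroxy to methoxy change is not neutral at this position: in this assay the methyl in place of hydrogen gives a 5.0-fold higher number from compound 2 to compound 4 (0.70 log units; beyond the scatter), so the hydrogen on this oxygen matters to the number in a way the earlier compounds could not reveal. The gain does not rest on that hydrogen alone, though, since the methoxy in place of hydrogen on the aromatic carbon still gives a 4.6-fold lower number from compound 1 to compound 4 (0.66 log units; beyond the scatter), and this step too lies beyond the scatter. Among these compounds, then, either oxygen-linked group lowers the number relative to the unsubstituted compound 1, with the hydroxy of compound 2 going further, and no measurement offered here accounts for the difference between the two groups.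

As far as these compounds go, it remains open how an amine, a fluorine or a plain methyl on the same aromatic carbon would compare, and so whether an oxygen at this place is needed at all. Also open, from the compounds shown here alone, are how a larger cap on the oxygen, such as ethyl or acetyl, would behave, and whether the methoxy would give a similar step on the ethyl chain of compound 3.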